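From 2-Methylphenyl to 3-Chlorophenyl on the Amide Carbonyl

This account rests on a few compounds, and the source may have more. Where it says the series, first, only, none or still open, it means among the compounds named here.

Measured in an assay on LtK cells with ATP-sensitive inward rectifier potassium channel 11 (Homo sapiens) as the target; on this read-out higher numbers stand for an effect only at larger amounts of compound and lower numbers for an effect already at smaller amounts:
- compound 1 `C/C=C/C(=O)Nc1c(C(O)(C(F)(F)F)C(F)(F)F)ccc2ccccc12` gives 72 nM
- compound 2 `O=C(CCc1ccccc1)Nc1c(C(O)(C(F)(F)F)C(F)(F)F)ccc2ccccc12` gives 1750 nM
- compound 3 `Cc1ccccc1C(=O)Nc1c(C(O)(C(F)(F)F)C(F)(F)F)ccc2ccccc12` gives 5550 nM

The three compounds share one core and differ only in the group attached to the carbonyl carbon of the amide. Compound 3 stands at the highest number of the three in this assay: a 3.2-fold higher number from compound 2 to compound 3 (0.50 log units; beyond the scatter), and a 77-fold higher number from compound 1 to compound 3 (1.89 log units; beyond the scatter). The step with the smallest group, prop-1-en-1-yl, gives the lowest number, and both larger groups sit well above it.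

Compound 4 `O=C(Nc1c(C(O)(C(F)(F)F)C(F)(F)F)ccc2ccccc12)c1cccc(Cl)c1` differs from compound 3 in one place: 3-chlorophenyl in place of 2-methylphenyl on a carbonyl carbon. Each of the three measured steps exchanges the whole group on that carbonyl carbon; the nearest in kind is the exchange of one seven-heavy-atom group for another, which moved by a 3.2-fold higher number from compound 2 to compound 3 (0.50 log units; beyond the scatter). Within the data shown here, no measured step exchanges one substituted phenyl for another, so the data give no direct guide to the size or direction of this change. Given that the two aromatic amides, compound 2 and compound 3, lie within a modest gap of each other, compound 4 is expected to stay in the same region, with a step of a 1.6-fold lower number from compound 3 to compound 4 (0.20 log units; within the scatter) and no confident direction. The estimate for compound 4 is 3500 nM, with a range from 800 nM to 15000 nM.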

Compound 4, half-maximal effective concentration: 98 nM
Compound 4: the middle estimate sits 36-fold (1.55 log units) above what was measured; the measured number lies below the stated range.
By their numbers in this assay, from the lowest: compounds 1 and 4 (each within the scatter of the next); then compound 2; then compound 3.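

In this assay, 3-chlorophenyl in place of 2-methylphenyl on the carbonyl carbon gives a 57-fold lower number from compound 3 to compound 4 (1.75 log units; beyond the scatter), a shift far larger than any the opening comparison of the two aromatic amides suggested. Among these compounds, this position therefore distinguishes between two single-ring groups with the same count of heavy atoms, which the earlier compounds, with no pair of substituted phenyls, could not show. An aromatic ring here also does not go with a high number in itself: the exchange for phenethyl gives an 18-fold lower number from compound 2 to compound 4 (1.25 log units; beyond the scatter), while the exchange for prop-1-en-1-yl gives a 1.4-fold higher number from compound 1 to compound 4 (0.13 log units; within the scatter), so the earlier impression that the smallest group stood alone at the low end does not hold, with compound 4 as the exception. Nothing in the material at hand accounts for this gap between the two phenyl groups.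

The compounds shown leave open whether the gain comes from the chlorine or from losing the 2-methyl group, and an unsubstituted phenyl on the same carbonyl carbon would give both a common reference. Also open, as far as these compounds go, is how a pyridine ring or a longer chain would read at this position.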